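Oxime versus benzoyl on a triazole thioether: paw edema

This account rests on a few compounds, and the source may have more. Where it says the series, first, only, none or still open, it means among the compounds named here.

Measured compounds and their values:
Compound 1 `COc1ccc(-c2nnc(SCC(=O)c3ccccc3)n2-c2ccccc2)cc1OC` gives 56%.
Compound 2 `C=CCn1c(SC/C(=N/O)c2ccccc2)nnc1-c1ccc(OC)cc1` gives 61%.
Compound 3 `COc1ccc(-c2nnc(SC/C(=N/O)c3ccccc3)n2-c2ccccc2)cc1OC` gives 55%.

These three were examined in a functional assay on the whole organism (strain albino) for inhibition, with Rattus norvegicus as the target, read by paw edema, with a stated time of 1 h, at a dose of 0.28 mmol/kg by the oral route; a lower number here means less inhibition, a higher number more inhibition at the dose given (going by the name of the read-out). In this assay compound 3 gives 55% and compound 1 gives 56%; the step of a number 1 percentage points higher from compound 3 to compound 1 (within the scatter) is small. The change behind that step is a group of 8 heavy atoms (7 carbon, 1 oxygen; one six-membered aromatic ring of carbon only) in place of a group of 9 heavy atoms (7 carbon, 1 nitrogen, 1 oxygen; one six-membered aromatic ring of carbon only), on a saturated chain carbon bound to a sulfur.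

Compound 2 gives 61% in this assay. Among the compounds with values here, its core differs from the core of compound 3, but the difference between the two cores is not broken down here, so no counted step from compound 2 to compound 3 is available; their two values lie within the scatter of each other.

The unmeasured compound 4 `C=CCn1c(SCC(=O)c2ccccc2)nnc1-c1ccc(OC)cc1` is derived from compound 2 by a group of 8 heavy atoms (7 carbon, 1 oxygen; one six-membered aromatic ring of carbon only) in place of a group of 9 heavy atoms (7 carbon, 1 nitrogen, 1 oxygen; one six-membered aromatic ring of carbon only), on a saturated chain carbon bound to a sulfur. This is the same change that was made from compound 3 to compound 1, and it occurs two times among the compounds shown, both at the same place on the chain carbon bound to sulfur.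

Because the step of a number 1 percentage points higher from compound 3 to compound 1 (within the scatter) from compound 3 to compound 1 stayed within the scatter, the corresponding step for compound 4 is expected to be of about the same size, no change at the digits printed from compound 2 to compound 4 (within the scatter). Compound 4 is therefore estimated to give 61% in this assay, with a likely range from 50% to 71%.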

Compound 4, a percentage reported as inhibition, in the whole organism at one dose (the size of the read-out at that dose, not a potency): 49%
For compound 4 the middle estimate is 12 percentage points above the measured one; the whole stated range lies above it.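

On the core of compound 2, benzoyl in place of the oxime-bearing group on the saturated chain carbon bound to a sulfur gives a number 12 percentage points lower from compound 2 to compound 4 (beyond the scatter) in this assay, a modest loss of inhibition at the dose given. Set beside the same change on the other core, this step cannot be told apart from the earlier one, so the series gives no firm sign that the core alters the outcome of the change: the same change on two cores in this assay, a number 1 percentage points higher (within the scatter) from compound 3 to compound 1 and a number 12 percentage points lower (beyond the scatter) from compound 2 to compound 4, 13 percentage points apart, within the scatter of two such steps. Within the data shown here, this does not show that the change carries over unaltered, since it rests on only two matched pairs, and the step on one core lies beyond the usual scatter while the step on the other lies within it.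

The compounds shown leave open whether the drop on the core of compound 2 would recur on further cores, and which part of the difference between the two cores, if any, matters for the size of the step. They also leave open how an amine or a carboxylic acid would fare in place of benzoyl on that chain carbon, and whether a longer chain between the sulfur and the aromatic ring would keep the inhibition of paw edema seen here.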